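Swapping the aryl group on the piperazine of compound 2

The source may report more compounds than this note shows. Statements on the series, on what has been measured and on what is new or still open speak of the compounds shown alone.

Compound 2 `Fc1ccc(N2CCN(CCCCCOc3ccc4c(c3)CCC4)CC2)cc1` stands highest of the three compounds measured in a functional assay on the whole organism for inhibition, with Mus musculus as the target, at a dose of 25 mg/kg by the oral route (a higher number here means more inhibition at the dose given (going by the name of the read-out), a lower number less inhibition), where compound 2 gives 58%. Its nearest neighbour, compound 1 `c1ccc(N2CCN(CCCCCOc3ccc4c(c3)CCC4)CC2)cc1`, gives 27%, and the only single-point step shown, a number 31 percentage points higher from compound 1 to compound 2 (beyond the scatter), came from fluoro in place of hydrogen on an aromatic carbon. Compound 3 `FC(F)(F)c1cccc(N2CCN(CCCOc3ccc4c(c3)CCC4)CC2)c1`, which carries a 3-(trifluoromethyl)phenyl on a shorter chain, gives 0% in this assay. Compound 4 `FC(F)(F)c1cccc(N2CCN(CCCCCOc3ccc4c(c3)CCC4)CC2)c1` differs from compound 2 by 3-(trifluoromethyl)phenyl in place of 4-fluorophenyl on an amine nitrogen in a ring. Among the compounds with values here, no measured step covers this exact change, so the account rests on compound 3 giving 0% while keeping the chain of compound 2. A step downward of a number 33 percentage points lower from compound 2 to compound 4 (beyond the scatter) is therefore expected, and compound 4 is estimated at 25%, within 0% to 55%.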

Compound 4, a percentage reported as inhibition, in the whole organism at one dose (the size of the read-out at that dose, not a potency): 33%
Compound 4: the middle estimate sits 8 percentage points below what was measured; measured number inside the range.
By their numbers in this assay, from the lowest: compound 3; then compounds 1 and 4 (each within the scatter of the next); then compound 2.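

At this amine nitrogen in a ring, fluoro and trifluoromethyl do not behave alike. In this assay the swap to 3-(trifluoromethyl)phenyl gives a number 25 percentage points lower from compound 2 to compound 4 (beyond the scatter) and so gives up much of the gain seen with 4-fluorophenyl, while trifluoromethyl in place of hydrogen gives only a number 6 percentage points higher from compound 1 to compound 4 (within the scatter). Nothing available explains this difference. Going by these compounds, what remains open is whether the step follows the group itself or its place on the phenyl ring, and what a chloro or methoxy group there would give.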